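Swapping the ring-bearing side chain on the shared core

The source may hold more compounds than are shown below. What is called first, only, known or untested is meant among the compounds shown, and "the series" means these compounds.

Of the compounds shown here, two of one series have been measured in an assay on isolated protein for inhibition of protein kinase C theta type (Homo sapiens), read by TR-FRET, with a stated time of 2 h; on this read-out lower numbers stand for stronger inhibition and higher numbers for weaker inhibition. Compound 1 `CO[C@H]1CC[C@H](Nc2cc(NCc3cnccc3C(F)(F)F)ncc2C#N)CC1` gives 1100 nM, and compound 2 `N#Cc1cnc(NCc2cnccc2C(F)(F)F)cc1NCCC1CCOCC1` gives 1200 nM. Compound 2 carries the higher of the two numbers, but the gap between the two is a 1.1-fold higher number from compound 1 to compound 2 (0.04 log units; within the scatter), so the two are indistinguishable on this assay. The next compound, compound 3 `N#Cc1cnc(NCc2cnccc2C(F)(F)F)cc1N[C@H]1CC[C@@H](C(N)=O)CC1`, keeps the shared core and differs from compound 2 only in the group on the nitrogen on the aromatic ring: 4-carbamoylcyclohexyl in place of 2-(oxan-4-yl)ethyl on a nitrogen on an aromatic ring. Within the data shown here, the one measured step that bears on this position, a 1.1-fold higher number from compound 1 to compound 2 (0.04 log units; within the scatter), shows that exchanging one such side chain for another left the number unchanged within the scatter. On that basis no step beyond the scatter is expected from compound 2 to compound 3, and the estimate is a 1.2-fold lower number from compound 2 to compound 3 (0.08 log units; within the scatter). Compound 3 is therefore expected to give about 1000 nM, with a likely range from 350 nM to 3000 nM.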

Compound 3, half-maximal inhibitory concentration: 7 nM
For compound 3 the middle estimate is 140-fold (2.15 log units) above the measured one; measured number outside the range, below it.
By their numbers in this assay, from the lowest: compound 3; then compounds 1 and 2 (each within the scatter of the next).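

The group on the nitrogen on an aromatic ring turns out to matter far more than the first two compounds suggested: in this assay, 4-carbamoylcyclohexyl in place of 2-(oxan-4-yl)ethyl gives a 170-fold lower number from compound 2 to compound 3 (2.23 log units; beyond the scatter). The comparison with the methoxy compound is the tighter one, as both side chains are built on a cyclohexyl ring, and it gives a 160-fold lower number from compound 1 to compound 3 (2.20 log units; beyond the scatter). A cyclohexyl ring alone is therefore not enough, and the large step goes with the carbamoyl group that the ring carries in place of methoxy.

Nothing measured here gives the reason for this step. From the compounds shown here alone, it remains open how much of the carbamoyl group is needed, and a carboxylic acid, an amine or a methyl ester in its place on the cyclohexyl ring would test that.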